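A few compounds are considered here, and "the series" means these few. Any claim that something is new, unique, unknown or untested is made for them only; others in the source may bear on it.

Compound 1 `CC(C)(C)n1ncc(OCc2nnc(-c3ccc(Cl)cc3Cl)s2)c(Cl)c1=O`: 62.2 ug/mL; compound 2 `Cc1ccc(-c2nnc(COc3cnn(C(C)(C)C)c(=O)c3Cl)o2)cc1`: 19.9 ug/mL.

In a functional assay on the whole organism for inhibition, with Mythimna separata as the target, with a stated time of 5 days (on this read-out lower numbers stand for an effect already at smaller amounts and higher numbers for an effect only at larger amounts of compound), compound 1 gives 62.2 ug/mL, the highest of the two numbers, while compound 2 gives 19.9 ug/mL, a lower number beyond the usual scatter. The two differ in more than one place, so their gap is read only as what the two values show. Compound 3 `CC(C)(C)n1ncc(OCc2nnc(-c3ccccc3F)s2)c(Cl)c1=O` differs from compound 1 in one place: 2-fluorophenyl in place of 2,4-dichlorophenyl on an aromatic carbon. Among the measured compounds shown here, no measured step of this kind is available. For compound 3 the expected shift is small, towards a lower number and near the edge of the scatter: a 1.2-fold lower number from compound 1 to compound 3 (0.09 log units; within the scatter). Compound 3 is therefore estimated at 50 ug/mL, within 18 ug/mL to 140 ug/mL.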

Compound 3, half-maximal effective concentration: 121 ug/mL
Compound 3: the middle estimate sits 2.4-fold (0.38 log units) below what was measured; the measured number falls inside the stated range.
By their numbers in this assay, from the lowest: compound 2; then compounds 1 and 3 (each within the scatter of the next).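

In this assay, putting 2-fluorophenyl in place of 2,4-dichlorophenyl on this aromatic carbon gives a 1.9-fold higher number from compound 1 to compound 3 (0.29 log units; within the scatter), a step that stays within the usual scatter. This first measured change at the position therefore does not separate compound 1 from compound 3, although the group that enters carries a different halogen pattern. No measurement of any property bears on this step. As far as these compounds go, what stays open is how this position responds to a group of another kind, such as an amine, a carboxylic acid or a longer alkyl chain in place of the halogenated phenyl.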